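Cytotoxicity of a Boron-Bearing Amide Series in Fibroblasts

The source may hold more compounds than are shown below. What is called first, only, known or untested is meant among the compounds shown, and "the series" means these compounds.

Compound 1 `O=C(CCc1cccc2c1B(O)OC2)Nc1ccccc1` opens the set. In an ADME assay on WI-38 cells (Homo sapiens) for cytotoxicity, read by MTT assay, with a stated time of 72 h (on this read-out lower numbers stand for stronger inhibition and higher numbers for weaker inhibition), compound 1 gives 30000 nM, the highest of the two numbers available, with compound 3 nearest. Compound 3 `C#Cc1ccccc1NC(=O)CCc1cccc2c1B(O)OC2` carries ethynyl in place of hydrogen on an aromatic carbon, and in this assay compound 3 gives 18000 nM; the step is a 1.7-fold lower number from compound 1 to compound 3 (0.22 log units; within the scatter). Compound 2 `CC(C)(C)OC(=O)Nc1ccc(NC(=O)CCc2cccc3c2B(O)OC3)cc1` carries (tert-butoxycarbonyl)amino in place of hydrogen on an aromatic carbon. In this assay compound 2 reaches only a limit, > 100000 nM. The step of an at least 3.3-fold higher number from compound 1 to compound 2 (0.52 log units; beyond the scatter) rests on (the limit of > 100000 nM in this assay, at which 1 of the 3 values shown sits). Compound 4 `N#Cc1ccc(-c2cccc(NC(=O)CCc3cccc4c3B(O)OC4)c2)cc1` differs from compound 1 as follows: 4-cyanophenyl in place of hydrogen on an aromatic carbon. Both measured steps replaced hydrogen on an aromatic carbon; one lay within the scatter, the other was at least modest. A step of a 1.3-fold higher number from compound 1 to compound 4 (0.12 log units; within the scatter) is therefore expected. Compound 4 is estimated at 40000 nM, between 15000 nM and 100000 nM.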

Compound 4, half-maximal inhibitory concentration: 12000 nM
Compound 4: the middle estimate sits 3.3-fold (0.52 log units) above what was measured, outside the stated range (below it).
By their numbers in this assay, from the lowest: compounds 4, 3 and 1 (each within the scatter of the next, the first and the last beyond it). At a limit, above all of these: compound 2.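

In this assay, 4-cyanophenyl on an aromatic carbon, meta to a large group, gives a 2.5-fold lower number from compound 1 to compound 4 (0.40 log units; beyond the scatter) and so provides the first step from compound 1 that is beyond the scatter towards a lower number. The ethynyl step stayed within the scatter, and compound 2 went the other way, so a large entering group need not bring a higher number at this kind of position. Nothing measured here accounts for the step.

Going by these compounds, it remains open whether the phenyl ring or the nitrile carries the change. A plain phenyl, or a carboxylic acid in place of the nitrile, would separate the two.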